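This account rests on a few compounds, and the source may have more. Where it says the series, first, only, none or still open, it means among the compounds named here.

Compound 1 `COc1ccc(CNC(=O)c2[nH]c3ccc(Cl)cc3c2S(=O)(=O)c2cc(C)cc(C)c2)cc1`: 39900 nM
Compound 2 `Cc1cc(C)cc(S(=O)(=O)c2c(C(=O)NCc3ccc(Cl)cc3)[nH]c3ccc(Cl)cc23)c1`: > 51200 nM (a limit)
Compound 3 `Cc1cc(C)cc(S(=O)(=O)c2c(C(=O)NCc3cccc(F)c3)[nH]c3ccc(Cl)cc23)c1`: > 53000 nM (a limit)

These results come from an ADME assay on MT4 cells (Homo sapiens) for cytotoxicity, read by MTT assay; on this read-out higher numbers stand for lower toxicity in this test and lower numbers for higher toxicity in this test. Compound 3 gives > 53000 nM, which is a limit and not a number. Compound 4 `Cc1cc(C)cc(S(=O)(=O)c2c(C(=O)NCc3ccc(N)cc3)[nH]c3ccc(Cl)cc23)c1` differs from it as follows: 4-aminophenyl in place of 3-fluorophenyl on a saturated chain carbon bound to an amide-type nitrogen. In words, this is 4-aminophenyl in place of 3-fluorophenyl on a saturated chain carbon bound to an amide-type nitrogen. Two measured changes at this place bear on it: an at least 1.3-fold higher number from compound 1 to compound 3 (0.12 log units; that floor lies within the scatter), and a step that the two limits leave unreadable from compound 2 to compound 3. Neither involves 4-aminophenyl, so the guide is loose. Given the small floor of an at least 1.3-fold higher number from compound 1 to compound 3 (0.12 log units; that floor lies within the scatter), no change beyond the usual scatter is expected, and the estimate is an at least 1.5-fold lower number from compound 3 to compound 4 (0.18 log units; that floor lies within the scatter). For compound 4 the estimated value is 35000 nM, with an expected range of 12000 nM to 70000 nM.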

Compound 4, half-maximal cytotoxic concentration: 6370 nM
Beside the measured number, compound 4's estimate is 5.5-fold (0.74 log units) above it, outside the stated range (below it).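

In this assay, among these compounds, 4-aminophenyl is the first group at this place to give a step beyond the scatter: an at least 8.3-fold lower number from compound 3 to compound 4 (0.92 log units; beyond the scatter), an at least 8.0-fold lower number from compound 2 to compound 4 (0.90 log units; beyond the scatter), and a 6.3-fold lower number from compound 1 to compound 4 (0.80 log units; beyond the scatter). The group on the saturated chain carbon bound to the amide-type nitrogen can therefore shift toxicity in this test, and compound 4 is the most toxic of the four shown.

On these data alone, whether this shift is specific to the amino group stays open, and 4-hydroxyphenyl or 4-(dimethylamino)phenyl would test that. Nothing shown here explains the shift.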